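The source may report more compounds than this note shows. Statements on the series, on what has been measured and on what is new or still open speak of the compounds shown alone.

Compounds measured in an ADME assay on HepG2 cells (Homo sapiens) for cytotoxicity, with a stated time of 72 h; a higher number here means that more compound is needed for the effect, a lower number that less compound is needed:
- Compound 1, `CSc1ccccc1NC(=O)Nc1cc(C)nc2ccccc12`: > 25000 nM, a limit of the assay and not a number.
- Compound 2, `Cc1cc(NC(=O)Nc2ccc(C(F)(F)F)cc2)c2ccccc2n1`: 23000 nM.
- Compound 3, `Cc1cc(NC(=O)Nc2ccc(SC(F)(F)F)cc2)c2ccccc2n1`: 20000 nM.

Compound 1 stands at the limit of > 25000 nM in this assay, at which 1 of the 3 values shown sits, so its place among the three can only be said as a limit: the other two values lie close to it, and no order among the three is shown. Compound 4, `Cc1cc(NC(=O)Nc2ccccc2F)c2ccccc2n1`, has not yet been measured in this assay. It differs from compound 1 in one place: fluoro in place of methylsulfanyl on an aromatic carbon.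

For the measured compounds named here, only one measured step is known, a 1.2-fold lower number from compound 2 to compound 3 (0.06 log units; within the scatter), and it concerns a different position of the shared core and a different pair of groups, so it bears on the present change only by showing that a single group swap on the outer ring left the read-out where it was. Going by the values given here, no measured step covers the exchange of methylsulfanyl for fluoro itself.

Compound 4 is therefore expected to sit near the three known values, with a step of a number no higher from compound 1 to compound 4 (the limit leaves the size open) that is not expected to exceed the scatter. The estimate for compound 4 is 25000 nM, with a range from 12000 nM to 50000 nM, and a fair chance that the assay again reports only a limit.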

Compound 4, half-maximal effective concentration: > 25000 nM
Compound 4: no number, only a limit; the forecaster's own chance of this, stated with the estimate: 55%; the middle value lies on the limit itself.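

No step from compound 1 to compound 4 can be read in this assay, as each of the two carries only a limit of the assay and not a number: the limit of > 25000 nM in this assay, at which 2 of the 4 values shown sit.

The compounds shown leave open whether fluoro and methylsulfanyl differ at all in this read-out, and by how much.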